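Adding a methyl to the sulfur chain of compound 3

The source may hold more compounds than are shown below. What is called first, only, known or untested is meant among the compounds shown, and "the series" means these compounds.

Three related compounds have been tested in an ADME assay on MT4 cells (Homo sapiens) for activation, read by MTT assay; on this read-out lower numbers stand for higher toxicity in this test and higher numbers for lower toxicity in this test. Compound 3 (`CCCSc1nc(C(CC)c2c(F)cccc2F)c(C)c(=O)[nH]1`) gives > 3000 nM, which is a limit and not a number. Compound 1 (`CCC(C)Sc1nc(C(CC)c2c(F)cccc2Cl)c(C)c(=O)[nH]1`) gives > 3000 nM, also a limit. Compound 2 (`CCC(c1nc(SC(C)C)[nH]c(=O)c1C)c1c(F)cccc1F`) gives > 30000 nM, again a limit. Compound 3 therefore has no exact place on the scale.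

Compound 4 (`CCC(C)Sc1nc(C(CC)c2c(F)cccc2F)c(C)c(=O)[nH]1`) differs from compound 3 by a single change, propyl to sec-butyl: methyl in place of hydrogen on a saturated chain carbon bound to a saturated chain carbon and a sulfur. Among the compounds with values here, the one measured step on a sulfur chain is a step that the two limits leave unreadable from compound 2 to compound 3, with propyl in place of isopropyl on a sulfur, so it offers no size to carry over. Compound 1 already carries (sec-butyl)sulfanyl, and its result is the limit of > 3000 nM in this assay, at which 2 of the 3 values shown sit.

With no readable size to go on, no step beyond the usual scatter is expected in this assay, in either direction. The estimated step runs a step that the limit leaves unreadable from compound 3 to compound 4. For compound 4 the expected value is 5000 nM, with an estimated range of 2000 nM to 30000 nM.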

Compound 4, half-maximal cytotoxic concentration: > 3000 nM
Compound 4 gave a limit, no number; the forecaster's own chance of this, stated with the estimate: 85%; the middle value lies beyond the limit too.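

Within the data shown here, compound 4 gives only a limit and not a number, as do compound 1, compound 2 and compound 3, so no step between them can be read. From the compounds shown here alone, whether the sulfur chain or fluoro in place of chloro changes the result in this assay stays open.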